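Swapping 4-fluorophenyl for 3-methylphenyl on the carbonyl

The source may hold more compounds than are shown below. What is called first, only, known or untested is meant among the compounds shown, and "the series" means these compounds.

Compound 1 `Cc1cc(C(=O)N2CCc3c(sc(NCc4ccccc4)c3C#N)C2)[nH]n1` gives 77.6% in an ADME assay (liver) for metabolic stability, with Liver microsome (Homo sapiens) as the target, read by LC-MS, using microsomes and NADPH, with a stated time of 30 min, tested at 1 uM; a lower number here means that less of the compound is left, a higher number that more of the compound is left
Compound 2 `N#Cc1c(NCc2ccccc2)sc2c1CCN(C(=O)c1ccc(F)cc1)C2` gives 49.4% in this assay

For the measured compounds named here, compound 2 stands lowest of the two measured compounds, with 49.4% in this assay so far. Compound 3 `Cc1cccc(C(=O)N2CCc3c(sc(NCc4ccccc4)c3C#N)C2)c1` differs from it by one exchange 3-methylphenyl in place of 4-fluorophenyl on a carbonyl carbon on a carbonyl carbon. Going by the values given here, the only measured step, a number 28.2 percentage points lower from compound 1 to compound 2 (beyond the scatter), replaced a 3-methyl-1H-pyrazol-5-yl group, so it says little about exchanging one six-membered aromatic ring of carbon only for another. No change beyond the scatter is therefore expected, and the expected step is a number 3.4 percentage points lower from compound 2 to compound 3 (within the scatter) in this assay overall. For compound 3 the estimated value is 46% (expected range 28% to 64%).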

Compound 3, percent of the compound remaining: 16.4%
Compound 3: middle estimate off by 29.6 percentage points, on the high side, outside the stated range (below it).
By their numbers in this assay, from the lowest: compound 3; then compound 2; then compound 1.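

In this assay, 3-methylphenyl in place of 4-fluorophenyl on the carbonyl carbon gives a number 33 percentage points lower from compound 2 to compound 3 (beyond the scatter), so two groups with the same heavy-atom count and the same ring type are not interchangeable at this position. Replacing 3-methyl-1H-pyrazol-5-yl with 3-methylphenyl gives a number 61.2 percentage points lower from compound 1 to compound 3 (beyond the scatter), and compound 1 stays highest of the three. Nothing available explains these steps. From the compounds shown here alone, it remains open whether an unsubstituted phenyl ring, or a phenyl ring carrying an amine or a carboxylic acid, would sit nearer compound 1 or compound 3.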